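Adding a Fluorine to the Benzoyl Ring of Compound 2

The source may hold more compounds than are shown below. What is called first, only, known or untested is meant among the compounds shown, and "the series" means these compounds.

Compound 2 `O=C(c1ccccc1)N1CCC(NCCSC(c2ccc(F)cc2)c2ccc(F)cc2)CC1` was characterised in an assay on membranes from Cortex for displacement of a labelled ligand from Sigma non-opioid intracellular receptor 1 (Cavia porcellus), read by scintillation counting, with a stated time of 120 min (on this read-out higher numbers stand for weaker inhibition and lower numbers for stronger inhibition), where compound 2 gives 2.03 nM. Among the compounds with values here, this is the lowest of the two numbers measured so far, but its only neighbour, compound 1 `Fc1ccc(C(SCCNC2CCN(Cc3ccccc3)CC2)c2ccc(F)cc2)cc1`, which in this assay gives 3.81 nM, sits within the scatter of it. Within the data shown here, the one measured step, a 1.9-fold lower number from compound 1 to compound 2 (0.27 log units; within the scatter), concerns benzoyl in place of benzyl and is itself within the scatter.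

Compound 3 `O=C(c1ccc(F)cc1)N1CCC(NCCSC(c2ccc(F)cc2)c2ccc(F)cc2)CC1` differs from compound 2 by fluoro in place of hydrogen on an aromatic carbon. Among the measured compounds shown here, no measured step involves a fluoro on this ring; the single step available changes the group on the ring nitrogen rather than the ring itself, so it bears on the new change only loosely. Nothing in these numbers therefore points to a step beyond the scatter, and the expected step is a 1.0-fold lower number from compound 2 to compound 3 (0.01 log units; within the scatter). Compound 3 is accordingly estimated to give 2 nM in this assay, with a likely range from 0.8 nM to 5 nM.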

Compound 3, inhibition constant: 32.1 nM
Beside the measured number, compound 3's estimate is 16-fold (1.21 log units) below it; measured number outside the range, above it.
By their numbers in this assay, from the lowest: compounds 2 and 1 (each within the scatter of the next); then compound 3.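

In this assay, the aromatic carbon para to a large group on the benzoyl ring proves sensitive to substitution: a single fluoro in place of hydrogen gives a 16-fold higher number from compound 2 to compound 3 (1.20 log units; beyond the scatter), whereas the earlier change on the ring nitrogen, a 1.9-fold lower number from compound 1 to compound 2 (0.27 log units; within the scatter), showed no such sensitivity. The result also limits what that earlier step implied, as the match between benzoyl and benzyl does not carry over to (4-fluorophenyl)carbonyl, which gives an 8.4-fold higher number from compound 1 to compound 3 (0.93 log units; beyond the scatter). Nothing available here accounts for the size of this step.

The compounds shown leave open whether a chlorine, a methyl or a methoxy group on this same carbon would give a comparable step. They also leave open whether fluoro on another carbon of this ring, or on the benzyl ring of compound 1, would do the same.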